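This account rests on a few compounds, and the source may have more. Where it says the series, first, only, none or still open, it means among the compounds named here.

In an ADME assay on a cell-free system (plasma, Homo sapiens), with a stated time of 30 min (on this read-out higher numbers stand for a more stable compound and lower numbers for a less stable compound), three compounds sharing one core have been measured. Compound 1 `COc1ccccc1C(=O)N[C@]1(OC)C(=O)N2C(C(=O)OCc3ccc(C(=O)O)cc3)=C(CSc3nnnn3C)CO[C@@H]21` gives 26%, compound 2 `CCCOc1ccccc1C(=O)N[C@]1(OC)C(=O)N2C(C(=O)OCc3ccc(C(=O)O)cc3)=C(CSc3nnnn3C)CO[C@@H]21` gives 26%, and compound 3 `CCC(C)Oc1ccccc1C(=O)N[C@]1(OC)C(=O)N2C(C(=O)OCc3ccc(C(=O)O)cc3)=C(CSc3nnnn3C)CO[C@@H]21` gives 39%, the highest of the three numbers. Compound 4 `CO[C@@]1(NC(=O)c2ccccc2Oc2ccccc2)C(=O)N2C(C(=O)OCc3ccc(C(=O)O)cc3)=C(CSc3nnnn3C)CO[C@@H]21` differs from compound 3 as follows: phenyl in place of sec-butyl on an oxygen on an aromatic ring. In words, this is phenyl in place of sec-butyl on an oxygen on an aromatic ring. Going by the values given here, no measured compound carries a ring at this place, so the evidence is indirect. Among the saturated chains, the step of no change at the digits printed from compound 1 to compound 2 (within the scatter) is not a real change, whereas the steps of a number 13 percentage points higher from compound 1 to compound 3 (beyond the scatter) and a number 13 percentage points higher from compound 2 to compound 3 (beyond the scatter) are modest. The lead of compound 3 therefore rests on the sec-butyl group alone, and phenyl is not expected to keep it. A modest fall is expected, back toward the level of compound 1 at 26%, and the estimated step is a number 11 percentage points lower from compound 3 to compound 4 (beyond the scatter). The estimate for compound 4 is 28%, with an expected range from 14% to 46%.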

Compound 4, percent of the compound remaining: 63%
Compound 4: the middle estimate sits 35 percentage points below what was measured; measured number outside the range, above it.
By their numbers in this assay, from the lowest: compounds 1 and 2 (each within the scatter of the next); then compound 3; then compound 4.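

In this assay, the oxygen on an aromatic ring can carry a ring as well as a saturated chain, and phenyl gives a clear gain over sec-butyl (a number 24 percentage points higher from compound 3 to compound 4 (beyond the scatter)). The gain is larger against the unbranched groups, propyl (a number 37 percentage points higher from compound 2 to compound 4 (beyond the scatter)) and methyl (a number 37 percentage points higher from compound 1 to compound 4 (beyond the scatter)), so the lead of compound 3 was not the ceiling at this place, and the group on this oxygen can move the number further than the chains alone showed. Nothing given here explains the rise.

From the compounds shown here alone, it remains open whether the gain needs an aromatic ring or any ring at all, which a cyclohexyl group on the same oxygen would test. Going by these compounds, it is also open how a benzyl group, or a phenyl carrying a fluorine or a methoxy group, would read at this place.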